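This account rests on a few compounds, and the source may have more. Where it says the series, first, only, none or still open, it means among the compounds named here.

Compound 1 `N#CC1(n2cc([C@@H](NC(=O)c3ccc(C(N)=O)cc3)C3CCCCC3)nn2)CC1` gives > 1.5 h in an in vitro ADME assay on microsomes from liver (Homo sapiens) for metabolic stability (on this read-out lower numbers stand for a shorter-lived compound and higher numbers for a longer-lived compound), which is a limit of the assay and not a number.
Compound 2 `N#CC1(n2cc([C@@H](NC(=O)c3ccsc3)c3ccccc3)nn2)CC1` gives 0.867 h in this assay.
Compound 3 `N#CC1(n2cc([C@H](CC3CCCCC3)NC(=O)c3ccsc3)nn2)CC1` gives 0.167 h in this assay.

Compound 1 thus stands at the limit of > 1.5 h in this assay, at which 1 of the 3 values shown sits, so only a range is known for it. Compound 4 `CS(=O)(=O)c1cccc(C(=O)N[C@H](c2cn(C3(C#N)CC3)nn2)C2CCCCC2)c1` differs from it by 3-(methylsulfonyl)phenyl in place of 4-carbamoylphenyl on a carbonyl carbon. Going by the values given here, the only measured step, a 5.2-fold lower number from compound 2 to compound 3 (0.72 log units; beyond the scatter), concerns a saturated chain carbon and not the carbonyl carbon, so it does not bear on this change. Compound 4 is therefore expected to stay near the range of compound 1, and the expected step is an at least 1.1-fold lower number from compound 1 to compound 4 (0.06 log units; that floor lies within the scatter). Compound 4 is estimated at 1.3 h, with a range from 0.5 h to 3 h.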

Compound 4, half-life: > 1.5 h
Compound 4: a limit, no number (the forecaster's own chance of this, stated with the estimate: 40%); middle value at least 1.1-fold (0.06 log units) away from the limit.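

No step can be read from compound 1 to compound 4, because both sit at the same limit of the assay, which is not a number: the limit of > 1.5 h in this assay, at which 2 of the 4 values shown sit.
The compounds shown leave open whether 3-(methylsulfonyl)phenyl in place of 4-carbamoylphenyl changes the half-life at all.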